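Acetyl for cyano on the aryl group of compound 2

This account rests on a few compounds, and the source may have more. Where it says the series, first, only, none or still open, it means among the compounds named here.

Measured compounds:
compound 1 `CCCCN(CC)c1nc(C)nc2c1NC(=O)CN2c1ccc(OC)cc1C`: 95 nM
compound 2 `CCCCN(CC)c1cc(C)nc2c1NCCN2c1ccc(C#N)cc1C`: 3.5 nM
compound 3 `CCCCN(CC)c1cc(C)nc2c1NC(=O)CN2c1ccc(C(C)=O)cc1C`: 5.8 nM

All three were tested in an assay on frontal cortex for displacement of a labelled ligand from corticotropin-releasing factor receptor 1 (Rattus norvegicus); on this read-out higher numbers stand for weaker inhibition and lower numbers for stronger inhibition. Compound 2 gives the smallest of the three numbers, but compound 3 lies within the usual scatter of it, so no order between these two can be claimed; compound 1 lies beyond the scatter and is the clear outlier of the set. Compound 3 already carries an acetyl group on its aryl ring, yet it also carries an amide carbonyl in the shared core that compound 2 lacks, so the two differ in more than one place and no single step can be read from them.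

Compound 4 `CCCCN(CC)c1cc(C)nc2c1NCCN2c1ccc(C(C)=O)cc1C` has not yet been measured in this assay. It is obtained from compound 2 by a single change: acetyl in place of cyano on an aromatic carbon. Since compound 3 with the same acetyl group gives 5.8 nM, a number within the scatter of compound 2, the step is expected to be small, with no direction beyond the scatter; the step from compound 2 to compound 4 is estimated as a 1.3-fold higher number from compound 2 to compound 4 (0.11 log units; within the scatter). Compound 4 is therefore expected to give about 4.5 nM, within a range from 1.5 nM to 14 nM.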

Compound 4, half-maximal inhibitory concentration: 8.2 nM
Compound 4: middle estimate off by 1.8-fold (0.26 log units), on the low side; low and high end bracket the measured number.
By their numbers in this assay, from the lowest: compounds 2, 3 and 4 (each within the scatter of the next, the first and the last beyond it); then compound 1.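

In this assay, going by these compounds alone, the exchange of cyano for acetyl on the aromatic carbon para to a large group gives the first comparison in the set that isolates a single place: a 2.3-fold higher number from compound 2 to compound 4 (0.37 log units; beyond the scatter), a modest step that lies just beyond the scatter. The earlier compounds shown here could not show this, since compound 2 and compound 3 differ in the shared core as well as in this group, and their values lie within the scatter of each other. Compound 3 and compound 4, which both carry the acetyl group and differ only in the core carbonyl, also lie within the scatter of each other, while no measurement shown here accounts for the step from cyano to acetyl.

The compounds shown leave open how this position responds to other groups, such as a carboxylic acid, an amine, or a longer acyl chain such as propionyl in place of acetyl. Compound 1 differs from each of the others in more than one place, so its distance from them cannot be assigned to any single change.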